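Replacing the phenyl group of compound 2

This account rests on a few compounds, and the source may have more. Where it says the series, first, only, none or still open, it means among the compounds named here.

Measured in an ADME assay on HEp-2 cells (Homo sapiens) for cytotoxicity; on this read-out lower numbers stand for higher toxicity in this test and higher numbers for lower toxicity in this test:
Compound 1 `Cc1ccnc(C)c1NC(=O)[C@@H]1CCCN1S(=O)(=O)c1cccc2cccnc12`: > 50000 nM (a limit)
Compound 2 `Cc1ccc(Cl)cc1NC(=O)[C@@H]1CCCN1S(=O)(=O)c1cccc2cccnc12`: 10000 nM

The entry for compound 1 is a limit, not a number. Going by the values given here, compound 2 gives 10000 nM, the only exact number in this assay so far.

Compound 3 `Cc1cc(NC(=O)[C@@H]2CCCN2S(=O)(=O)c2cccc3cccnc23)n(C(C)(C)C)n1` differs from compound 2 at one place: 3-methyl-1-(tert-butyl)-1H-pyrazol-5-yl in place of 5-chloro-2-methylphenyl on an amide-type nitrogen. Among the compounds with values here, one measured step bears on this change: an at least 5.0-fold lower number from compound 1 to compound 2 (0.69 log units; beyond the scatter). That step brought in the same 5-chloro-2-methylphenyl that now leaves. Within the data shown here, the group entering compound 3 is not the one that left compound 1, so this step is only a loose guide, but it points towards a higher number. The expected change is modest: a 2.0-fold higher number from compound 2 to compound 3 (0.30 log units; within the scatter). For compound 3 the estimated value is 20000 nM, with an expected range of 7000 nM to 50000 nM.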

Compound 3, half-maximal cytotoxic concentration: > 50000 nM
Compound 3 gave a limit, no number; the forecaster's own chance of this, stated with the estimate: 35%; at least 2.5-fold (0.39 log units) between middle value and limit.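

On the amide-type nitrogen, 3-methyl-1-(tert-butyl)-1H-pyrazol-5-yl in place of 5-chloro-2-methylphenyl gives an at least 5.0-fold higher number from compound 2 to compound 3 (0.69 log units; beyond the scatter) in this assay. A five-membered aromatic ring with nitrogen, like the pyridine ring of compound 1, therefore goes with a higher number than the carbon-only ring of compound 2, which now has the lowest number of the three, with steps beyond the scatter to both others. The step between compound 1 and compound 3 cannot be read, because both values are limits: the limit of > 50000 nM in this assay, at which 2 of the 3 values shown sit.

The compounds shown leave open whether the chlorine or the carbon-only ring goes with the lower number. A plain phenyl or a 2-methylphenyl without the chlorine on the same nitrogen would separate the two.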